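The compounds below may be only part of what the source reports. "The series", "measured", "known", "first", "only" and "open" are said of these compounds alone.

Series notes. The shared core is common to compound 1 `CC(C)n1ncc2c(C(=O)NCc3cn(-c4ccc(I)cc4)nn3)cccc21`, compound 2 `CC(C)n1ncc2c(C(=O)NCc3cn(-c4ccc([N+](=O)[O-])cc4)nn3)cccc21` and compound 3 `Cc1ccccc1-n1cc(CNC(=O)c2cccc3c2cnn3C(C)C)nn1`; they differ only in the group on an aromatic nitrogen of a five-membered aromatic ring with 3 nitrogen. In a functional assay on HepG2 cells (Homo sapiens) for inhibition, read by MTT assay, with a stated time of 72 h (on this read-out higher numbers stand for weaker inhibition and lower numbers for stronger inhibition), compound 1 gives > 40000 nM, a limit of the assay. Compound 2 gives > 40000 nM in this assay, likewise a limit. Compound 3 gives > 40000 nM in this assay, again a limit. Compound 3 thus stands at the limit shared by the whole set, as the limit of > 40000 nM in this assay, at which 3 of the 3 values shown sit, records. The three steps among the measured compounds, a step that the two limits leave unreadable from compound 1 to compound 2, a step that the two limits leave unreadable from compound 1 to compound 3 and a step that the two limits leave unreadable from compound 2 to compound 3, cannot be read, as both ends of each sit at a limit.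

Compound 4 `CC(C)n1ncc2c(C(=O)NCc3cn(Cc4ccccc4)nn3)cccc21` differs from compound 3 by benzyl in place of 2-methylphenyl on an aromatic nitrogen. Among the compounds with values here, no measured step bears readably on this change; the unreadable steps into compound 3 show only that exchanging one group on that nitrogen for another left every value at the limit. No step beyond the scatter in this assay is expected, and the step expected is a step that the limit leaves unreadable from compound 3 to compound 4. Compound 4 is estimated at 60000 nM, with a range from 20000 nM to 200000 nM, and the assay will most likely again report only a limit.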

Compound 4, half-maximal inhibitory concentration: 13700 nM
For compound 4 the middle estimate is 4.4-fold (0.64 log units) above the measured one, and the stated range ends above it.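

In this assay, within the data shown here, the steps among compound 1, compound 2 and compound 3 cannot be read, so the earlier compounds could not show whether the group on the aromatic nitrogen of the five-membered ring moves the read-out at all; compound 4 shows that it can, with an at least 2.9-fold lower number from compound 3 to compound 4 (0.46 log units; beyond the scatter). This change keeps the same atoms, joined differently, so a read-out beyond the scatter appears without any change in the heavy-atom count or ring count of the group, and the exchange of benzyl for the two para-free names on record also reads clearly, with an at least 2.9-fold lower number from compound 2 to compound 4 (0.46 log units; beyond the scatter) and with an at least 2.9-fold lower number from compound 1 to compound 4 (0.46 log units; beyond the scatter). Of the four groups shown on this nitrogen, only benzyl gives a value off the shared limit: the limit of > 40000 nM in this assay, at which 3 of the 4 values shown sit.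

From the compounds shown here alone, whether this belongs to benzyl itself or to any group with a chain between the nitrogen and the ring stays open, and a longer chain such as 2-phenylethyl would bear on that. Also open, going by these compounds, is how far the value of compound 4, 13700 nM, responds to substitution on the benzyl ring, for instance by an amine or a carboxylic acid.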